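Swapping isopentyl for tert-butyl on the hydroxy-bearing carbon

This account rests on a few compounds, and the source may have more. Where it says the series, first, only, none or still open, it means among the compounds named here.

Measured in a functional assay on a cell-free system (plasma, Homo sapiens), with a stated time of 3 min; on this read-out lower numbers stand for stronger inhibition and higher numbers for weaker inhibition:
- Compound 1 `O=C(NCc1cc(Cl)ccc1-n1cnnn1)[C@@H]1CC=NN1C(=O)[C@H](O)c1ccccc1`: 840 nM
- Compound 2 `CC(C)(C)C[C@@H](O)C(=O)N1N=CC[C@H]1C(=O)NCc1cc(Cl)ccc1-n1cnnn1`: 590 nM
- Compound 3 `CC(C)CC[C@@H](O)C(=O)N1N=CC[C@H]1C(=O)NCc1cc(Cl)ccc1-n1cnnn1`: 630 nM

The value of compound 3 lies within the scatter of the values of both compound 1 and compound 2, so the three numbers give no real order. The next structure, compound 4 `CC(C)(C)[C@@H](O)C(=O)N1N=CC[C@H]1C(=O)NCc1cc(Cl)ccc1-n1cnnn1`, has not yet been measured. It carries tert-butyl in place of isopentyl on a saturated chain carbon bound to a carbonyl carbon and an oxygen on a saturated carbon.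

Two measured steps exchange the group at this same place. They are a 1.4-fold lower number from compound 1 to compound 2 (0.15 log units; within the scatter) and a 1.3-fold lower number from compound 1 to compound 3 (0.12 log units; within the scatter). A third step, a 1.1-fold higher number from compound 2 to compound 3 (0.03 log units; within the scatter), alters the chain further along, with isobutyl in place of tert-butyl. All three stayed within the scatter, even though phenyl, neopentyl and isopentyl were exchanged. Among the measured compounds shown here, no measured compound has tert-butyl directly at this place, so the evidence is indirect and the range is kept wide. In this assay, no step beyond the scatter is expected. The estimated step is a 1.0-fold higher number from compound 3 to compound 4 (0.01 log units; within the scatter). Compound 4 is expected at 650 nM, with an estimated range of 250 nM to 1700 nM.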

Compound 4, half-maximal inhibitory concentration: 1400 nM
For compound 4 the middle estimate is 2.2-fold (0.33 log units) below the measured one, and the stated range covers the measured number.
By their numbers in this assay, from the lowest: compounds 2, 3, 1 and 4 (each within the scatter of the next, the first and the last beyond it).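

In this assay, the place on the saturated chain carbon bound to a carbonyl carbon and an oxygen on a saturated carbon now shows its first steps beyond the scatter, though both are modest: a 2.2-fold higher number from compound 3 to compound 4 (0.35 log units; beyond the scatter) and a 2.4-fold higher number from compound 2 to compound 4 (0.38 log units; beyond the scatter). Neopentyl and isopentyl therefore go with stronger inhibition than tert-butyl here, so this place is not indifferent to the group it carries, as the earlier compounds alone had suggested; compound 1 does not fit a simple ranking, however, since with phenyl it shows a 1.7-fold higher number from compound 1 to compound 4 (0.22 log units; within the scatter), a step within the scatter. Nothing shown explains the loss seen with tert-butyl.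

The compounds shown leave open whether the change belongs to tert-butyl itself or would also appear with isopropyl or cyclohexyl at this place. They also leave open how a longer chain, or an amine carried on the end of the isopentyl chain, would read out on the same shared core.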